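A few compounds are considered here, and "the series" means these few. Any claim that something is new, unique, unknown or untested is made for them only; others in the source may bear on it.

Compound 1 `CCCC[C@@H](CCn1cncn1)c1ccc(Cl)cc1` gives 18.7 ug/mL in an ADME assay on RD cells (Homo sapiens) for cytotoxicity, read by MTT assay, with a stated time of 3 days; a lower number here means that less compound is tolerated, a higher number that more compound is tolerated. Compound 2 `CCCC[C@H](CCn1cncn1)c1ccc(OC)cc1` gives 28.3 ug/mL in this assay.

Compound 2 has the higher of the two numbers, but the gap to compound 1 lies within the scatter, so the two cannot be ranked. Compound 3 `CCCC[C@@H](CCn1cncn1)c1ccc(OC)cc1` is related to compound 2 by one difference: the two compounds have the same atoms and bonds and differ only in configuration as drawn: 1 of 1 stereo elements differ; a stereocentre at a saturated chain carbon is drawn R in compound 2 and S in compound 3. For the measured compounds named here, no measured pair shows what such a change does here, so the size of the step is unknown. Compound 3 is expected to give about 28 ug/mL in this assay, between 15 ug/mL and 55 ug/mL, a step of a 1.0-fold lower number from compound 2 to compound 3 (0.00 log units; within the scatter) that is estimated to stay within the scatter.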

Compound 3, half-maximal cytotoxic concentration: 39.4 ug/mL
For compound 3 the middle estimate is 1.4-fold (0.15 log units) below the measured one; the measured number falls inside the stated range.
By their numbers in this assay, from the lowest: compounds 1, 2 and 3 (each within the scatter of the next, the first and the last beyond it).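

Swapping the stereocentre at the saturated chain carbon gives a 1.4-fold higher number from compound 2 to compound 3 (0.14 log units; within the scatter) in this assay, so this pair shows no separation between the two configurations as drawn: the fact that compounds 2 and 3 differ only in the configuration as drawn. Methoxy in place of chloro on an aromatic carbon gives a 2.1-fold higher number from compound 1 to compound 3 (0.32 log units; beyond the scatter), the first single change here to pass beyond the scatter, though the step is modest. From the compounds shown here alone, whether the chloro compounds show the same indifference to configuration remains open, as does what an amine or a carboxylic acid on that aromatic carbon would give.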